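Chloro to ethyl on the pendant aryl ring

The source may report more compounds than this note shows. Statements on the series, on what has been measured and on what is new or still open speak of the compounds shown alone.

In a functional assay on CCRF-CEM cells (Homo sapiens) for inhibition, read by cell counting, with a stated time of 3 days (a higher number here means a weaker inhibitor, a lower number a stronger inhibitor), compound 1 `C=C(Br)C(=O)Nc1cccc(-c2cn3nc(-c4ccc(OC)c(OC)c4)sc3n2)c1` gives 380 nM and compound 2 `C=C(Br)C(=O)Nc1cccc(-c2cn3nc(-c4ccc(Cl)cc4)sc3n2)c1` gives 3200 nM, the higher of the two numbers. Compound 3 `Nc1cccc(-c2cn3nc(-c4ccc(Cl)cc4)sc3n2)c1` gives only a limit, > 250000 nM. The step of an 8.4-fold higher number from compound 1 to compound 2 (0.93 log units; beyond the scatter) is modest; the step of an at least 78-fold higher number from compound 2 to compound 3 (1.89 log units; beyond the scatter) is large and concerns a different part of the molecule. Compound 4 `C=C(Br)C(=O)Nc1cccc(-c2cn3nc(-c4ccc(CC)cc4)sc3n2)c1` differs from compound 2 by ethyl in place of chloro on an aromatic carbon. Only the first step touches this ring, and it replaced a larger group; chloro to ethyl is a smaller exchange, so in this assay no step beyond the scatter is expected, though a modest one either way is possible. Compound 4 is therefore expected to give about 2500 nM, within 800 nM to 8000 nM, which means an expected 1.3-fold lower number from compound 2 to compound 4 (0.11 log units; within the scatter).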

Compound 4, half-maximal inhibitory concentration: 3400 nM
For compound 4 the middle estimate is 1.4-fold (0.13 log units) below the measured one; measured number inside the range.
By their numbers in this assay, from the lowest: compound 1; then compounds 2 and 4 (each within the scatter of the next). At a limit, above all of these: compound 3.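

With a 1.1-fold higher number from compound 2 to compound 4 (0.03 log units; within the scatter) in this assay, chloro and ethyl cannot be told apart at this position, although ethyl brings 2 heavy atoms for the 1 of chlorine. With an 8.9-fold higher number from compound 1 to compound 4 (0.95 log units; beyond the scatter), 4-ethylphenyl stands apart from 3,4-dimethoxyphenyl just as 4-chlorophenyl does, so that difference does not hang on chloro itself. Nothing at hand gives a reason for either step.

From the compounds shown here alone, whether a longer chain, an amine or a carboxylic acid in place of chloro would keep this level stays open. So does whether a single methoxy group, rather than two, would match compound 1.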